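From open chain to 1-aminocyclopentyl on a carbonyl carbon

The compounds below may be only part of what the source reports. "The series", "measured", "known", "first", "only" and "open" are said of these compounds alone.

Measured so far in a functional assay on U-87MG ATCC cells (Homo sapiens) for antiproliferative activity; on this read-out higher numbers stand for weaker inhibition and lower numbers for stronger inhibition:
- compound 1 (`CC[C@H](N)C(=O)N1CCc2c(C)c3c(n2-c2ccc(C(N)=O)c(c2)N[C@@H](C)[C@H](C)C1)CC(C)(C)CC3=O`): (45 nM)
- compound 2 (`Cc1c2c(n3c1CCN(C(=O)[C@@H](N)C(C)C)C[C@@H](C)[C@H](C)Nc1cc-3ccc1C(N)=O)CC(C)(C)CC2=O`): (48 nM)

Compound 2 stands within the scatter of compound 1, so the two cannot be ranked against each other. The compound still to be measured is compound 3 (`Cc1c2c(n3c1CCN(C(=O)C1(N)CCCC1)C[C@@H](C)[C@H](C)Nc1cc-3ccc1C(N)=O)CC(C)(C)CC2=O`), and it differs from compound 2 in one group (1-aminocyclopentyl in place of 1-amino-2-methylpropyl on a carbonyl carbon). In words, 1-aminocyclopentyl stands in place of 1-amino-2-methylpropyl on a carbonyl carbon whose other neighbour is an amide-type nitrogen in a ring. The entering group brings a five-membered non-aromatic ring of carbon only.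

Going by the values given here, only one measured step bears on this change. That step is a methyl in place of hydrogen on a saturated chain carbon (a 1.1-fold higher number from compound 1 to compound 2 (0.03 log units; within the scatter)), and it lies within the scatter. Among the compounds with values here, no measured compound carries a ring in this group, so the evidence is thin. No shift beyond the scatter is therefore expected, and the estimated step is small (a 1.1-fold higher number from compound 2 to compound 3 (0.06 log units; within the scatter)). In this assay, the estimate for compound 3 is 55 nM, with an expected range from 20 nM to 150 nM as its span.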

Compound 3, half-maximal inhibitory concentration: 44 nM
For compound 3 the middle estimate is 1.3-fold (0.10 log units) above the measured one; low and high end bracket the measured number.
By their numbers in this assay, from the lowest: compounds 3, 1 and 2 (each within the scatter of the next).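

In this assay, 1-aminocyclopentyl in place of 1-amino-2-methylpropyl on the carbonyl carbon gives a 1.1-fold lower number from compound 2 to compound 3 (0.04 log units; within the scatter) and 1-aminocyclopentyl in place of 1-aminopropyl gives a 1.0-fold lower number from compound 1 to compound 3 (0.01 log units; within the scatter) so both steps from the open chains to the ring lie within the scatter. The position, on a carbonyl carbon whose other neighbour is an amide-type nitrogen in a ring, therefore accepts a five-membered non-aromatic ring of carbon only without a shift beyond the scatter, and the same holds for a group with no defined stereocentre, whereas each open-chain group shown carries one. Nothing measured on these compounds offers an explanation of this outcome.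

From the compounds shown here alone, all three compounds keep an amine on the carbon bound to the carbonyl, so it remains open how a hydroxyl group in place of that amine, or a plain cyclopentyl, would read in this assay on this carbonyl carbon. Going by these compounds, it is equally open whether a cyclohexyl ring bearing the same amine, or a cyclobutyl one, would stay within the scatter of these three compounds.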